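Pyridin-4-yl for pyridin-3-yl on a second core

A few compounds are considered here, and "the series" means these few. Any claim that something is new, unique, unknown or untested is made for them only; others in the source may bear on it.

Compound 1 `C/C(=N/Nc1nc(-c2ccc(F)cc2)cs1)c1cccnc1` carries a pyridin-3-yl group on a carbon with a double bond to nitrogen. In an in vitro assay on BTI-TN-5B1-4 cells for inhibition of Amine oxidase [flavin-containing] A (Homo sapiens), read by Amplex Red, with a stated time of 15 min, tested at 100 uM (on this read-out higher numbers stand for more inhibition at the one concentration tested (going by the name of the read-out) and lower numbers for less inhibition), compound 1 gives 40%. Compound 2 `C/C(=N/Nc1nc(-c2ccc(F)cc2)cs1)c1ccncc1` differs from it in one place, (pyridin-4-yl in place of pyridin-3-yl on a carbon with a double bond to nitrogen), and the step of no change at the digits printed from compound 1 to compound 2 (within the scatter) shows that this swap left the read-out where it was; in this assay compound 2 gives 40%.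

Compound 3 `Fc1ccc(-c2csc(N/N=C\c3cccnc3)n2)c(F)c1` is built on a second core. How that core differs from the core of compound 1 is not broken down here. In this assay compound 3 gives 40%, level with compound 1 and compound 2 at the digits reported and within the usual scatter of such measurements.

Compound 4 `Fc1ccc(-c2csc(N/N=C\c3ccncc3)n2)c(F)c1` has not been measured. It differs from compound 3 by pyridin-4-yl in place of pyridin-3-yl on a carbon with a double bond to nitrogen. Within the data shown here, this is the same kind of change as the one made between compound 1 and compound 2, though the surroundings are not identical: in compound 1 the carbon that carries the group has a saturated chain carbon as a further neighbour, whereas in compound 3 its other neighbour is only the double-bonded nitrogen. The matching swap between compound 1 and compound 2 gave no change at the digits printed from compound 1 to compound 2 (within the scatter). On that basis a step of no change at the digits printed from compound 3 to compound 4 (within the scatter) is expected. Compound 4 is therefore estimated at 40%, with a likely range from 28% to 52%.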

Compound 4, a percentage reported as inhibition, at one concentration (the size of the read-out at that concentration, not a potency): "not active" (no number reported)
No number was reported for compound 4, so the estimate cannot be set against anything.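

In this assay, among these compounds, compound 4 is reported only as "not active", without a number, so no step from compound 3 to compound 4 can be read. No measurement shown here offers an explanation for this result. The compounds shown leave open whether pyridin-4-yl in place of pyridin-3-yl has the same effect on the core of compound 3 as on the core of compound 1.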